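This account rests on a few compounds, and the source may have more. Where it says the series, first, only, none or still open, it means among the compounds named here.

Compound 1 `Nc1ncnc2c(C(=O)Nc3cccc4c3c(Br)nn4Cc3ccccc3)csc12`: 1010 nM
Compound 2 `Nc1ncnc2c(C(=O)Nc3cccc4c3c(Br)nn4Cc3cccnc3)csc12`: 77 nM
Compound 3 `Nc1ncnc2c(C(=O)Nc3cccc4c3c(Br)nn4Cc3ccncc3)csc12`: 135 nM

In a functional assay on NFS-60 cells (Mus musculus) for inhibition, with a stated time of 72 h (a lower number here means a stronger inhibitor of growth, a higher number a weaker inhibitor of growth), compound 2 has the lowest number of the three; compound 3 sits within the scatter of it, with a 1.8-fold higher number from compound 2 to compound 3 (0.24 log units; within the scatter), while compound 1 lies well apart, with a 13-fold lower number from compound 1 to compound 2 (1.12 log units; beyond the scatter). Compound 4 `C#CCn1nc(Br)c2c(NC(=O)c3csc4c(N)ncnc34)cccc21` differs from compound 2 by ethynyl in place of pyridin-3-yl on a saturated chain carbon bound to an aromatic nitrogen. Among the compounds with values here, no measured step removes the ring at this place; the two that touch it, a 13-fold lower number from compound 1 to compound 2 (1.12 log units; beyond the scatter) and a 7.5-fold lower number from compound 1 to compound 3 (0.87 log units; beyond the scatter), exchange one six-membered aromatic ring for another and show that the group on this saturated chain carbon moves the number strongly. With the ring gone and only a triple bond outside aromatic rings in its place, a large rise in the number is expected, a 10-fold higher number from compound 2 to compound 4 (1.02 log units; beyond the scatter). Compound 4 is therefore estimated at 800 nM, in the range 200 nM to 3200 nM.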

Compound 4, concentration for 50% growth inhibition: > 10000 nM
Compound 4 gave a limit, no number (the forecaster's own chance of this, stated with the estimate: 5%); middle value at least 12-fold (1.09 log units) from the limit.
By their numbers in this assay, from the lowest: compounds 2 and 3 (each within the scatter of the next); then compound 1. At a limit, above all of these: compound 4.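

In this assay compound 4 gives a limit, not a number: the limit of > 10000 nM in this assay, at which 1 of the 4 values shown sits. Ethynyl at this place gives an at least 120-fold higher number from compound 2 to compound 4 (2.11 log units; beyond the scatter) and an at least 74-fold higher number from compound 3 to compound 4 (1.86 log units; beyond the scatter), and even against the phenyl ring it gives an at least 9.9-fold higher number from compound 1 to compound 4 (0.99 log units; beyond the scatter). Within the data shown here, the earlier exchanges showed only that one six-membered aromatic ring differs from another, whereas these steps show that all three rings give lower numbers here than ethynyl does.

From the compounds shown here alone, what stays open is whether an aromatic ring is required on this saturated chain carbon, or whether a cyclohexyl ring, a longer chain or an amine would also give low numbers.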